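Replacing naphthalen-1-yl with 4-aminophenyl

This account rests on a few compounds, and the source may have more. Where it says the series, first, only, none or still open, it means among the compounds named here.

Measured in a functional assay on MDA-MB-231 cells (Homo sapiens) for inhibition, read by MTT assay, with a stated time of 48 h; on this read-out higher numbers stand for weaker inhibition and lower numbers for stronger inhibition:
- compound 1 `COc1ccc(-c2cc(-c3cc(OC)c(OC)c(OC)c3)nc(-c3ccccc3)n2)c(OC)c1`: 1440 nM
- compound 2 `COc1cc(-c2cc(-c3ccc(O)cc3O)nc(-c3ccccc3)n2)cc(OC)c1OC`: 810 nM
- compound 3 `COc1cc(-c2cc(-c3cccc4ccccc34)nc(-c3ccccc3)n2)cc(OC)c1OC`: 3240 nM

Compound 3 stands highest of the three at 3240 nM, beyond the scatter from both others. Compound 4 `COc1cc(-c2cc(-c3ccc(N)cc3)nc(-c3ccccc3)n2)cc(OC)c1OC` carries 4-aminophenyl in place of naphthalen-1-yl on an aromatic carbon.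

Two modest steps bear on this: a 2.3-fold higher number from compound 1 to compound 3 (0.35 log units; beyond the scatter) and a 4.0-fold higher number from compound 2 to compound 3 (0.60 log units; beyond the scatter). Both end at naphthalen-1-yl with a higher number, whereas the step between the two phenyl-bearing compounds, a 1.8-fold lower number from compound 1 to compound 2 (0.25 log units; within the scatter), stays within the scatter. Read in reverse, they suggest a modest fall in this assay, though no aminophenyl compound has been measured. The expected change is a 2.9-fold lower number from compound 3 to compound 4 (0.47 log units; beyond the scatter). For compound 4 the estimated value is 1100 nM, with an expected range of 400 nM to 3000 nM.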

Compound 4, half-maximal inhibitory concentration: 1010 nM
Beside the measured number, compound 4's estimate is 1.1-fold (0.04 log units) above it; the measured number falls inside the stated range.
By their numbers in this assay, from the lowest: compounds 2, 4 and 1 (each within the scatter of the next); then compound 3.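

In this assay, 4-aminophenyl gives a 3.2-fold lower number from compound 3 to compound 4 (0.51 log units; beyond the scatter), so at this position the high number of compound 3 is specific to naphthalen-1-yl among the four groups shown. The one-ring groups are not separated: a 1.2-fold higher number from compound 2 to compound 4 (0.10 log units; within the scatter) and a 1.4-fold lower number from compound 1 to compound 4 (0.15 log units; within the scatter) both lie within the scatter, so the amine matches neither a gain nor a loss against the dihydroxy and dimethoxy patterns. No measurement shown gives a reason for the naphthalen-1-yl difference.

From the compounds shown here alone, it remains open whether the amine contributes at all, or whether any one-ring group would serve here. A plain phenyl, or a carboxylic acid or dimethylamino group in place of the amine, would test this.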